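Hydrazone series: relocating the methoxy group

The source may hold more compounds than are shown below. What is called first, only, known or untested is meant among the compounds shown, and "the series" means these compounds.

Compound 1 `C(=N/N(Cc1ccccc1)Cc1ccccc1)\c1ccccc1` gives 1500 nM in an assay on liver (Sus scrofa) for inhibition of glucose-6-phosphatase catalytic subunit 1 (Homo sapiens), using microsomes; on this read-out lower numbers stand for stronger inhibition and higher numbers for weaker inhibition. Compound 2 `C/C(=N\N(Cc1ccccc1)Cc1ccccc1)c1ccccc1` gives 25000 nM in this assay. Compound 3 `COc1ccc(/C=N/N(Cc2ccccc2)Cc2ccccc2)cc1` gives 220 nM in this assay, the lowest of the three numbers. Within the data shown here, the step of a 6.8-fold lower number from compound 1 to compound 3 (0.83 log units; beyond the scatter) is the only measured one that concerns the methoxy group; no measured pair compares two positions of that group on the ring, so the next step is not anchored. Compound 4 `COc1ccccc1/C=N/N(Cc1ccccc1)Cc1ccccc1` differs from compound 3 by 2-methoxyphenyl in place of 4-methoxyphenyl on a carbon with a double bond to nitrogen. Without a positional comparison in hand, a modest rise in the number, beyond the scatter but short of the level of compound 1, is the working expectation. The expected step is a 2.7-fold higher number from compound 3 to compound 4 (0.44 log units; beyond the scatter). Compound 4 is estimated at 600 nM, in a range from 150 nM to 2500 nM.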

Compound 4, half-maximal inhibitory concentration: > 100000 nM
Compound 4: only a limit was reported (the forecaster's own chance of this, stated with the estimate: 3%); middle value at least 160-fold (2.22 log units) away from the limit.
By their numbers in this assay, from the lowest: compound 3; then compound 1; then compound 2. At a limit, above all of these: compound 4.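

On this carbon with a double bond to nitrogen, the methoxy position decides the outcome: 2-methoxyphenyl in place of 4-methoxyphenyl, with the same atoms joined differently, gives a large loss (an at least 450-fold higher number from compound 3 to compound 4 (2.65 log units; beyond the scatter)). Methoxy in place of hydrogen therefore has no single direction of effect, since compound 4 also falls well behind the unsubstituted compound (an at least 66-fold higher number from compound 1 to compound 4 (1.82 log units; beyond the scatter)). Compound 4 is reported only as a limit, so both steps are bounds: the limit of > 100000 nM in this assay, at which 1 of the 4 values shown sits.

Going by these compounds, it remains open whether this loss is specific to methoxy. An amine or a fluorine in place of the methoxy of 2-methoxyphenyl would separate the effect of the group from that of its place.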